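The source may report more compounds than this note shows. Statements on the series, on what has been measured and on what is new or still open speak of the compounds shown alone.

Measured so far:
- compound 1 `Nc1nc(NCc2cccs2)nc2sc(-c3ccco3)nc12` — in a functional assay on CHO cells for agonist activity at adenosine receptor A2b (Homo sapiens), read by scintillation counting and cAMP accumulation, with a stated time of 150 min, in the presence of a further agent that is not named here (a lower number here means a stronger inhibitor, a higher number a weaker inhibitor), compound 1 gives 75 nM
- compound 2 `Nc1nc(NCc2ccccn2)nc2sc(-c3ccco3)nc12` — in this assay compound 2 gives 95 nM

Among the measured compounds shown here, compound 1 stands at the lowest of the two numbers, but the only other number, that of compound 2, lies within the scatter of it: a 1.3-fold higher number from compound 1 to compound 2 (0.10 log units; within the scatter). The two values therefore show no difference worth reading.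

Compound 3 `Nc1nc(NCc2cccs2)nc2sc(-c3cccs3)nc12` differs from compound 1 in one place: thiophen-2-yl in place of furan-2-yl on an aromatic carbon. For the measured compounds named here, the single measured step, from compound 1 to compound 2, changes the group on the saturated chain carbon, not the group on the aromatic carbon of the core, so no measured pair bears on the present change. With nothing in this direction to go on, the expectation is for no step beyond the scatter. Compound 3 is expected to give 110 nM, with a range from 45 nM to 280 nM. The expected step is a 1.5-fold higher number from compound 1 to compound 3 (0.17 log units; within the scatter).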

Compound 3, half-maximal inhibitory concentration: 547 nM
For compound 3 the middle estimate is 5.0-fold (0.70 log units) below the measured one; the measured number lies above the stated range.
By their numbers in this assay, from the lowest: compounds 1 and 2 (each within the scatter of the next); then compound 3.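

Swapping furan-2-yl for thiophen-2-yl on the aromatic carbon gives a 7.3-fold higher number from compound 1 to compound 3 (0.86 log units; beyond the scatter), although the counts of heavy atoms, hydrogen-bond donors and hydrogen-bond acceptors stay the same and the ring size is unchanged, with sulfur taking the place of oxygen. This position therefore responds to a change that the chain position has not been shown to register: the only step there, a 1.3-fold higher number from compound 1 to compound 2 (0.10 log units; within the scatter), stays within the scatter. Nothing on hand accounts for the size of the step at the aromatic carbon.

Going by these compounds, whether the same swap carries the same step with pyridin-2-yl on the chain carbon remains open. So does the reading in this assay for a phenyl ring or a morpholine on this aromatic carbon, and whether furan-2-yl is matched by any other group there.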